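The compounds below may be only part of what the source reports. "The series", "measured", "known", "first", "only" and "open" are said of these compounds alone.

Three compounds share one core and differ only in the aryl group carried on the ring with one nitrogen. Compound 1 `COc1cc2c(Oc3ccc(NC(=O)c4cc(-c5ccc(F)cc5)ccn4)cc3F)ccnc2cc1OCCCN1CCCCC1` gives 250 nM in a functional assay on NCI-H460 cells (Homo sapiens) for cytotoxicity, read by MTT assay, with a stated time of 72 h; on this read-out higher numbers stand for weaker inhibition and lower numbers for stronger inhibition. Compound 2 `COc1cc2c(Oc3ccc(NC(=O)c4cc(-c5ccccc5F)ccn4)cc3F)ccnc2cc1OCCCN1CCCCC1` gives 130 nM in this assay. Compound 3 `COc1cc2c(Oc3ccc(NC(=O)c4cc(-c5ccccc5C)ccn4)cc3F)ccnc2cc1OCCCN1CCN(C)CC1` gives 150 nM in this assay, the second highest of the three numbers and within the scatter of both of the others. Among the compounds with values here, the only step between two measured compounds that differ in one place is a 1.9-fold lower number from compound 1 to compound 2 (0.28 log units; within the scatter). The unmeasured compound 4 `COc1ccc(-c2ccnc(C(=O)Nc3ccc(Oc4ccnc5cc(OCCCN6CCN(C)CC6)c(OC)cc45)c(F)c3)c2)cc1` differs from compound 3 by 4-methoxyphenyl in place of 2-methylphenyl on an aromatic carbon. Within the data shown here, no measured step exchanges this same pair of groups; the one step that alters the same aryl group, between compound 1 and compound 2, stayed within the scatter, so the change to compound 4 is expected to produce no step beyond the scatter in this assay, an expected no change at the digits printed from compound 3 to compound 4 (within the scatter). Compound 4 is therefore estimated at 150 nM in this assay, with an expected range from 60 nM to 400 nM.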

Compound 4, half-maximal inhibitory concentration: 370 nM
The estimate for compound 4 lay 2.5-fold (0.39 log units) below the measured number; low and high end bracket the measured number.
By their numbers in this assay, from the lowest: compounds 2, 3, 1 and 4 (each within the scatter of the next, the first and the last beyond it).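

In this assay, within the data shown here, the aryl group on the aromatic carbon opposite the ring nitrogen moved the number beyond the scatter for the first time, with a 2.5-fold higher number from compound 3 to compound 4 (0.39 log units; beyond the scatter). The earlier step, a 1.9-fold lower number from compound 1 to compound 2 (0.28 log units; within the scatter), had stayed within the scatter, so this position does not respond alike to every aryl exchange, and 4-methoxyphenyl in place of 2-methylphenyl goes with weaker inhibition. No available evidence bears on why this exchange shifts the number.

The exchange alters both the substituent and its place on the phenyl ring, so the compounds shown cannot separate the two; 2-methoxyphenyl or 4-methylphenyl at this position would do so. As far as these compounds go, it also remains open how this position would respond to a phenyl ring carrying an amine or a carboxylic acid.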